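Formyl entering the shared core: cytotoxicity notes

This account rests on a few compounds, and the source may have more. Where it says the series, first, only, none or still open, it means among the compounds named here.

Two compounds carry a measurement in a functional assay on L1210 cells (Mus musculus) for cytotoxicity, with a stated time of 48 h; a lower number here means a stronger inhibitor, a higher number a weaker inhibitor. Compound 1 `O=c1oc2ccccc2cc1-c1cn2nc(Cc3ccc(Cl)cc3)sc2n1` stands only at a limit: in this assay compound 1 gives > 10000 nM, a limit of the assay rather than a number, as the limit of > 10000 nM in this assay, at which 1 of the 2 values shown sits, records. Compound 2 `Clc1ccc(Cc2nn3c(Br)c(-c4ccccc4)nc3s2)cc1` likewise reaches only a limit; in this assay compound 2 gives > 250000 nM, a limit as well, as the limit of > 250000 nM in this assay, at which 1 of the 2 values shown sits, records. Since neither value is a number, compound 1 cannot be ordered against compound 2; both simply sit at limits. Compound 3 `O=Cc1c(-c2cc3ccccc3oc2=O)nc2sc(Cc3ccc(Cl)cc3)nn12` is not yet measured. It differs from compound 1 by formyl in place of hydrogen on an aromatic carbon. Among the measured compounds shown here, no step between measured compounds exists against which to scale this change, and the two limits give no direction for it, so no movement beyond the scatter is expected either way. For compound 3 the estimate in this assay is 20000 nM, with a range of 5000 nM to 100000 nM. The expected step is a step that the limit leaves unreadable from compound 1 to compound 3. A result reported only as a limit is expected to remain the likely outcome.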

Compound 3, half-maximal inhibitory concentration: 890 nM
For compound 3 the middle estimate is 22-fold (1.35 log units) above the measured one, outside the stated range (below it).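

Formyl in place of hydrogen on an aromatic carbon of the five-membered aromatic ring with 2 nitrogen gives, in this assay, an at least 11-fold lower number from compound 1 to compound 3 (1.05 log units; beyond the scatter). This is the only readable movement in the series, and it shows that this position, next to the ring atom that bears a large group, responds to substitution; compound 3 is also the only compound shown with a number rather than a limit. The full size of the step cannot be read, since compound 1 stands only at a limit: the limit of > 10000 nM in this assay, at which 1 of the 3 values shown sits.

Whether the change belongs to formyl itself or to any group on this carbon stays open, as no other group at this place on the same core is shown. Hydroxymethyl, a carboxylic acid or a nitrile there would separate these readings, and compound 2 differs from compound 3 in more than one place, so it offers no such comparison.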